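Replacing the phenyl of compound 2

The source may hold more compounds than are shown below. What is called first, only, known or untested is meant among the compounds shown, and "the series" means these compounds.

In a functional assay on the whole organism (Hindlimb, strain albino) with Mus musculus as the target, in the maximal electroshock model, with a stated time of 0.5 h (on this read-out higher numbers stand for an effect only at larger amounts of compound and lower numbers for an effect already at smaller amounts), compound 2 `O=C(/C=C/c1ccccc1)Nc1nc2ccccc2s1` gives 646 umol/kg and compound 1 `O=C(/C=C/c1ccc(Cl)cc1)Nc1nc2ccccc2s1` gives 367 umol/kg, so the two stand within the scatter of each other. Compound 3 `O=C(/C=C/OC1=CC=C1)Nc1nc2ccccc2s1` carries the change (a group of 5 heavy atoms (4 carbon, 1 oxygen; one four-membered non-aromatic ring of carbon only) in place of a group of 6 heavy atoms (6 carbon; one six-membered aromatic ring of carbon only), on a double-bonded chain carbon bound to a double-bonded chain carbon). Going by the values given here, the one measured step, a 1.8-fold higher number from compound 1 to compound 2 (0.25 log units; within the scatter), is hydrogen in place of chloro and lies within the scatter. Among the compounds with values here, no measured pair replaces the phenyl, so this step bears on the change only weakly. No shift beyond the scatter is expected in this assay, in either direction, and the range stays wide. The expected step is a 1.2-fold lower number from compound 2 to compound 3 (0.07 log units; within the scatter). Compound 3 is estimated at 550 umol/kg, with an expected range of 220 umol/kg to 1300 umol/kg.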

Compound 3, dose for half-maximal effect: 781 umol/kg
Compound 3: the middle estimate sits 1.4-fold (0.15 log units) below what was measured, within the range that was stated.
By their numbers in this assay, from the lowest: compounds 1, 2 and 3 (each within the scatter of the next, the first and the last beyond it).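

In this assay, putting the group of 5 heavy atoms, with its four-membered non-aromatic ring, in place of phenyl stays within the scatter: a 1.2-fold higher number from compound 2 to compound 3 (0.08 log units; within the scatter). At this place, then, a six-membered aromatic ring is not needed to stay level with compound 2. Set against the larger chloro-bearing group of compound 1, the same group gives a modest step beyond the scatter: a 2.1-fold higher number from compound 1 to compound 3 (0.33 log units; beyond the scatter). No measured property of these compounds bears on either step.

The compounds shown leave open how an amine or a longer chain at this place would read in this assay. Also open, as far as these compounds go, is whether any group here gives a lower number than compound 1.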